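Removing one 4-methoxyphenyl from compound 1

The source may hold more compounds than are shown below. What is called first, only, known or untested is meant among the compounds shown, and "the series" means these compounds.

Among the compounds with values here, in a functional assay on A549 cells (Homo sapiens) for cytotoxicity, read by MTT assay, with a stated time of 68 h (on this read-out higher numbers stand for weaker inhibition and lower numbers for stronger inhibition), compound 1 `COc1ccc(-c2cc(NC(=O)C(Cl)Cl)cc(-c3ccc(OC)cc3)c2)cc1` gives 20800 nM, the only actual number so far. Compound 2 `O=C(Nc1cccc(-c2ccccn2)c1)C(Cl)Cl` reads > 50000 nM in this assay, and this is a limit of the assay, not a number.

Next in line is compound 3 `COc1ccc(-c2cccc(NC(=O)C(Cl)Cl)c2)cc1`, which differs from compound 1 as follows: hydrogen in place of 4-methoxyphenyl on an aromatic carbon. This puts hydrogen in place of 4-methoxyphenyl on an aromatic carbon. Within the data shown here, no measured step yet sizes this change. The expected direction in this assay is toward weaker inhibition and leans on the limit of compound 2 > 50000 nM, a compound with no 4-methoxyphenyl group. The expected change, a 1.4-fold higher number from compound 1 to compound 3 (0.16 log units; within the scatter), is small and may not clear the usual scatter. For compound 3 the estimated value is 30000 nM, with an expected range of 12000 nM to 50000 nM.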

Compound 3, half-maximal inhibitory concentration: 8530 nM
Compound 3: the middle estimate sits 3.5-fold (0.55 log units) above what was measured; measured number below the stated range.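

Hydrogen in place of 4-methoxyphenyl on an aromatic carbon gives a 2.4-fold lower number from compound 1 to compound 3 (0.39 log units; beyond the scatter) in this assay, the first step in the series that can be sized. At this carbon, a second 4-methoxyphenyl group is therefore not needed for the activity of compound 1, and in this pair its presence goes with weaker inhibition. This rests on a single pair, and the data shown give no cause for the step.

Open, on these data alone, is whether a methyl group, a fluorine atom or an amine at this carbon would read closer to compound 3 or to compound 1. Also open, as far as these compounds go, is how far the remaining 4-methoxyphenyl group of compound 3 can be changed, for example by moving the methoxy group or replacing it with a carboxylic acid.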